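Exchanging oxan-3-yl for an oxetanyl piperidine on the sulfonyl sulfur

The source may hold more compounds than are shown below. What is called first, only, known or untested is meant among the compounds shown, and "the series" means these compounds.

In an ADME assay on microsomes from liver (Homo sapiens) for pharmacokinetics, read by LC-MS, with a stated time of 60 min, tested at 1 uM (on this read-out lower numbers stand for slow clearance and higher numbers for fast clearance), compound 1 (`CCCn1cc(S(=O)(=O)c2ccc(CNC(=O)N3Cc4ccncc4C3)cc2)cn1`) gives 11 mL/min/kg and compound 2 (`O=C(NCc1ccc(S(=O)(=O)C2CCOCC2)cc1)N1Cc2ccncc2C1`) gives 6 mL/min/kg while compound 3 (`O=C(NCc1ccc(S(=O)(=O)C2CCCOC2)cc1)N1Cc2ccncc2C1`) gives 7 mL/min/kg and so stands within the scatter of both. Compound 4 (`O=C(NCc1ccc(S(=O)(=O)C2CCN(C3COC3)CC2)cc1)N1Cc2ccncc2C1`) carries 1-(oxetan-3-yl)piperidin-4-yl in place of oxan-3-yl on a sulfonyl sulfur. Three measured exchanges on that sulfur bear on this: a 1.8-fold lower number from compound 1 to compound 2 (0.26 log units; within the scatter) and a 1.6-fold lower number from compound 1 to compound 3 (0.20 log units; within the scatter) as well as a 1.2-fold higher number from compound 2 to compound 3 (0.07 log units; within the scatter) all lie within the scatter. None of them involves the entering group, so they guide the expectation only loosely. The expected step is a 1.3-fold higher number from compound 3 to compound 4 (0.11 log units; within the scatter) and so stays within the scatter. In this assay compound 4 is estimated at 9 mL/min/kg (5 mL/min/kg to 17 mL/min/kg).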

Compound 4, clearance: 10 mL/min/kg
Compound 4: the middle estimate sits 1.1-fold (0.05 log units) below what was measured; the measured number falls inside the stated range.
By their numbers in this assay, from the lowest: compounds 2, 3, 4 and 1 (each within the scatter of the next).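

In this assay, within the data shown here, the sulfonyl sulfur carries 1-(oxetan-3-yl)piperidin-4-yl, the first group here with a four-membered ring and two rings in all, and a 1.4-fold higher number from compound 3 to compound 4 (0.15 log units; within the scatter) and a 1.7-fold higher number from compound 2 to compound 4 (0.22 log units; within the scatter) as well as a 1.1-fold lower number from compound 1 to compound 4 (0.04 log units; within the scatter) all lie within the scatter. So this larger group leaves the clearance number indistinguishable from those of the pyrazolyl and oxanyl compounds. Nothing available explains this result. The compounds shown leave open whether the oxetane itself matters, since a piperidin-4-yl with a free amine or a simple N-methyl group is absent from this set. From the compounds shown here alone, a carboxylic acid on that ring also remains untested here.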